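Swapping a Pyrimidine for a Bromothiophene beside the Sulfoxide

The source may hold more compounds than are shown below. What is called first, only, known or untested is meant among the compounds shown, and "the series" means these compounds.

Compound 1 `Cc1cnc(C[S+]([O-])C(c2ccccc2)c2ccccc2)nc1` is the weakest of three measured compounds in an assay on HEK293 cells for inhibition of sodium-dependent dopamine transporter (Homo sapiens), read by scintillation counting, with stated times of 5 min and 1 min; a higher number here means a weaker inhibitor, a lower number a stronger inhibitor: compound 1 gives 156000 nM. Compound 2 `[O-][S+](Cc1nc(C(F)(F)F)no1)C(c1ccccc1)c1ccccc1` gives 43700 nM, and compound 3 `Cc1ccc(C(c2ccc(C)cc2)[S+]([O-])Cc2cccs2)cc1` gives 5800 nM, both clearly lower than compound 1. The untested compound 4 `[O-][S+](Cc1ccsc1Br)C(c1ccccc1)c1ccccc1` differs from compound 1 in one place: 2-bromothiophen-3-yl in place of 5-methylpyrimidin-2-yl on a saturated chain carbon bound to a sulfur. For the measured compounds named here, no single-change step between measured compounds is available to guide this change directly. Still, because compound 3 gives 5800 nM, a move toward lower numbers is expected, though compound 3 also differs from compound 4 elsewhere. The step from compound 1 to compound 4 is expected to be a 7.8-fold lower number from compound 1 to compound 4 (0.89 log units; beyond the scatter), beyond the scatter. Compound 4 is therefore estimated at 20000 nM, within 6000 nM to 70000 nM.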

Compound 4, half-maximal inhibitory concentration: 29300 nM
Compound 4: the middle estimate sits 1.5-fold (0.17 log units) below what was measured; low and high end bracket the measured number.
By their numbers in this assay, from the lowest: compound 3; then compounds 4 and 2 (each within the scatter of the next); then compound 1.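

For the compounds shown here, this is the first comparison that changes only this position, so the effect of the group can be read on its own. With 2-bromothiophen-3-yl in place of 5-methylpyrimidin-2-yl on a saturated chain carbon bound to a sulfur, the result is a 5.3-fold lower number from compound 1 to compound 4 (0.73 log units; beyond the scatter) and the rest of the molecule stays the same. Nothing available explains why the number moves. Still open, on these data alone, is whether the bromine or the thiophene ring accounts for this step, and how an amine or a carboxylic acid at this position would compare.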